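The source may hold more compounds than are shown below. What is called first, only, known or untested is meant among the compounds shown, and "the series" means these compounds.

Working notes on the series, read in an ADME assay on BJ cells (Homo sapiens) for cytotoxicity, with a stated time of 72 h (on this read-out higher numbers stand for an effect only at larger amounts of compound and lower numbers for an effect already at smaller amounts), as the only read-out. In this assay compound 1 (`CCc1ccc(-c2nc3c(c(C)nn3-c3ccccc3)c(-c3ccccc3I)c2C#N)cc1`) gives > 20000 nM as a limit of the assay and not a number. Compound 2 (`CCc1ccc(-c2nc3c(c(C)nn3-c3ccccc3)c(-c3ccccc3F)c2C#N)cc1`) gives > 20000 nM as a limit too, so its standing is known only as a limit. Among the measured compounds shown here, the sole measured step is a step that the two limits leave unreadable from compound 1 to compound 2 and it offers no size to carry forward. All that the series shows so far is the limit of > 20000 nM in this assay, at which 2 of the 2 values shown sit, and nothing finer.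

Compound 3 (`CCc1ccc(-c2nc3c(c(C)nn3-c3ccccc3)c(-c3ccccc3S(C)(=O)=O)c2C#N)cc1`) carries methylsulfonyl in place of fluoro on an aromatic carbon, ortho to a large group (methylsulfonyl in place of fluoro on an aromatic carbon). For the measured compounds named here, no measured step covers this exchange. The exchange from iodo to fluoro at the same place gave a step that the two limits leave unreadable from compound 1 to compound 2 and so supplies no direction. The expectation is therefore no step beyond the scatter, with a limit again the likeliest report. The expected move is a number no higher from compound 2 to compound 3 (the limit leaves the size open) and no more. In this assay compound 3 is estimated at 20000 nM (expected range 9000 nM to 40000 nM) for now.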

Compound 3, half-maximal effective concentration: > 20000 nM
Compound 3 was reported as a limit; the forecaster's own chance of this, stated with the estimate: 80%; the middle value sits exactly at the limit.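

Compound 3 comes back as a limit of the assay and not a number, as do compound 1 and compound 2, so no step among the three can be read in this assay: the limit of > 20000 nM in this assay, at which 3 of the 3 values shown sit.

The compounds shown leave open whether iodo, fluoro and methylsulfonyl differ at all in this read-out, and by how much.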